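Amide variation in one sulfonamide series: working notes

The source may hold more compounds than are shown below. What is called first, only, known or untested is meant among the compounds shown, and "the series" means these compounds.

Compound 1 `CCN(CC)C(=O)C(C)N1CCN(S(=O)(=O)c2ccc(C(C)(C)C)cc2)CC1`: in an ADME assay on HepG2 cells (Homo sapiens) for inhibition, with a stated time of 48 h (a lower number here means that less compound is needed, a higher number that more compound is needed for the effect), compound 1 gives > 40000 nM, which is a limit of the assay.
Compound 2 `C[C@@H](C(=O)N1CC2CC2C1)N1CCN(S(=O)(=O)c2ccc(C(C)(C)C)cc2)CC1`: in this assay compound 2 gives > 40000 nM, again a limit.
Compound 3 `CC(C(=O)N1CC2CC2C1)N1CCN(S(=O)(=O)c2ccc(C(C)(C)C)cc2)CC1`: in this assay compound 3 gives > 40000 nM, also a limit.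

Compound 3 therefore stands at the limit, and so do the two neighbours measured beside it; the common position of all three values is the limit itself (the limit of > 40000 nM in this assay, at which 3 of the 3 values shown sit). The step that the two limits leave unreadable from compound 1 to compound 3 is unreadable, since both ends sit at the limit. The step that the two limits leave unreadable from compound 2 to compound 3 is likewise unreadable, and the two compounds differ only in that one is drawn with a defined configuration and the other without (the fact that one of compounds 2 and 3 is drawn with a defined configuration and the other without, at the place where they differ).

Compound 4 `CC(C(=O)N1C[C@H]2CCC[C@H]2C1)N1CCN(S(=O)(=O)c2ccc(C(C)(C)C)cc2)CC1` carries the change (a group of 8 heavy atoms (7 carbon, 1 nitrogen; one five-membered non-aromatic ring of carbon only, one five-membered non-aromatic ring with 1 hetero atom) in place of a group of 6 heavy atoms (5 carbon, 1 nitrogen; one three-membered non-aromatic ring of carbon only, one five-membered non-aromatic ring with 1 hetero atom), on a carbonyl carbon). Among the measured compounds shown here, neither measured step gives a readable size for any amide change, and no measured compound shows a number rather than a limit. The step that the limit leaves unreadable from compound 3 to compound 4 is accordingly expected to show nothing beyond the scatter, in the sense that compound 4 is expected to remain at the limit. For compound 4 the estimate is 60000 nM, within 25000 nM to 150000 nM, with a limit the most likely outcome.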

Compound 4, half-maximal effective concentration: > 40000 nM
Compound 4: no number, only a limit; the forecaster's own chance of this, stated with the estimate: 85%; the middle value lies beyond the limit too.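

Compound 4 gives > 40000 nM as its value, which is a limit of the assay. The steps from compound 1 and from compound 3 to compound 4 therefore cannot be read, and all values shown sit at one place: the limit of > 40000 nM in this assay, at which 4 of the 4 values shown sit.

The compounds shown leave open whether any of these amides reaches a measurable value in this assay and how they would rank.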